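The source may hold more compounds than are shown below. What is called first, only, known or untested is meant among the compounds shown, and "the series" means these compounds.

Working notes on the series, read out in an ADME assay on L6 cells (Rattus norvegicus) for cytotoxicity; a lower number here means a stronger inhibitor, a higher number a weaker inhibitor. Compound 3 `COc1ccc(C2CC3(N(C)C)CC(O)C2C(c2ccc(OC)cc2)C3)cc1` gives 63400 nM, the higher of the two numbers available. Compound 1 `O=C1CC2(N3CCCC3)CC(c3ccccc3)C1C(c1ccccc1)C2` gives 26500 nM, and the gap between these two lies beyond the usual scatter. Compound 2 `COc1ccc(C2CC3(N4CCCCC4)CC(=O)C2C(c2ccc(OC)cc2)C3)cc1` adds no number, its entry being "not determined" (no result reported), so the series rests on two values only.

The next compound to read is compound 4 `COc1ccc(C2CC3(N4CCCCC4)CC(O)C2C(c2ccc(OC)cc2)C3)cc1`, which carries piperidin-1-yl in place of dimethylamino on a saturated ring carbon of compound 3: piperidin-1-yl in place of dimethylamino on a saturated ring carbon. The hydroxy group and both 4-methoxyphenyl groups stay as they are.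

Among the compounds with values here, no measured pair differs in one place only, so no direct precedent exists for this exchange, and the expectation is weakly anchored. Within the data shown here, the only other number, compound 1 at 26500 nM, lies lower than that of compound 3, and this gives a slight lean in direction and no reliable size. A small step to a lower number in this assay, not clearly beyond the scatter, is therefore expected. The expected step is a 1.6-fold lower number from compound 3 to compound 4 (0.20 log units; within the scatter). For compound 4 the estimated value is 40000 nM, with an expected range of 15000 nM to 100000 nM.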

Compound 4, half-maximal inhibitory concentration: 44600 nM
Compound 4: the middle estimate sits 1.1-fold (0.05 log units) below what was measured; low and high end bracket the measured number.
By their numbers in this assay, from the lowest: compounds 1, 4 and 3 (each within the scatter of the next, the first and the last beyond it).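

Within the data shown here, this is the first exchange that can be read in one place: in this assay, piperidin-1-yl in place of dimethylamino on the saturated ring carbon gives a 1.4-fold lower number from compound 3 to compound 4 (0.15 log units; within the scatter), with the hydroxy group and both 4-methoxyphenyl groups unchanged. Among these compounds, at this position, then, replacing an open dimethylamino group with a six-membered non-aromatic ring leaves the read-out within the scatter, so this assay does not separate these two amine groups, and the single exchange gives no basis for a trend with the size of the group. No measured information accompanies this result that could account for it.

The compounds shown leave open whether an amine group with a further hetero atom in the ring, such as morpholin-4-yl or piperazin-1-yl, or a small primary amino group on the same carbon would move the number beyond the scatter. They also leave open how much the hydroxy group itself contributes, as no single-place exchange at that ring atom, for example to a methoxy group or a fluorine atom, can be read here.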